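The source may report more compounds than this note shows. Statements on the series, on what has been measured and on what is new or still open speak of the compounds shown alone.

Measured compounds in a functional assay on HepG2 cells (Homo sapiens) for cytotoxicity, read by MTT assay, with a stated time of 48 h; a higher number here means a weaker inhibitor, a lower number a stronger inhibitor:
- compound 1 `C=CCSc1nnc(CC)n1N1C(=O)c2ccccc2C1=O`: > 200000 nM, a limit of the assay
- compound 2 `CCc1nnc(SCc2ccccc2)n1N1C(=O)c2ccccc2C1=O`: > 200000 nM, a limit of the assay

Compound 2 stands at the assay limit, as does compound 1, so that a step that the two limits leave unreadable from compound 1 to compound 2 cannot be read. the limit of > 200000 nM in this assay, at which 2 of the 2 values shown sit, is all the evidence at hand. Compound 3 `COc1cc(-c2nnc(SCc3ccccc3)n2N2C(=O)c3ccccc3C2=O)cc(OC)c1OC` differs from compound 2 by 3,4,5-trimethoxyphenyl in place of ethyl on an aromatic carbon. Going by the values given here, no measured step bears on this change: the only step, from compound 1 to compound 2, is unreadable, and no ring-bearing analogue is known here. A step of an at least 1.3-fold lower number from compound 2 to compound 3 (0.12 log units; that floor lies within the scatter) in this assay is therefore expected only loosely, with a limit the most likely outcome. Compound 3 is estimated at 150000 nM, within 40000 nM to 600000 nM.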

Compound 3, half-maximal inhibitory concentration: > 200000 nM
Compound 3 was reported as a limit; the forecaster's own chance of this, stated with the estimate: 65%; middle value at least 1.3-fold (0.12 log units) from the limit.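

Compound 3 gives > 200000 nM in this assay, a limit of the assay. Going by these compounds alone, compound 2 also sits at a limit, so no step to compound 3 can be read. The compounds shown leave open which change on the shared core, if any, would give a measurable value.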